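The source may hold more compounds than are shown below. What is called first, only, known or untested is meant among the compounds shown, and "the series" means these compounds.

In a functional assay on MCF-10A cells (Homo sapiens) for antiproliferative activity, with a stated time of 48 h (on this read-out lower numbers stand for an effect already at smaller amounts and higher numbers for an effect only at larger amounts of compound), three compounds sharing one core have been measured. Compound 1 `COc1ccc2nc(C)cc(NCc3ccncc3)c2c1` gives 40900 nM, compound 2 `COc1ccc2nc(C)cc(NCc3ccccc3F)c2c1` gives 14000 nM, and compound 3 `COc1ccc2nc(C)cc(NCc3c(F)cccc3F)c2c1` gives 13600 nM. Compound 3 therefore stands level with compound 2, and both show lower numbers than compound 1.

The next compound, compound 4 `COc1ccc2nc(C)cc(NCc3c(F)cccc3C(F)(F)F)c2c1`, keeps the core and differs from compound 3 in one group: trifluoromethyl in place of fluoro on an aromatic carbon, ortho to a large group and meta to a fluoro group (trifluoromethyl in place of fluoro on an aromatic carbon).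

Among the compounds with values here, two measured steps bear on this change. Exchanging pyridin-4-yl for 2-fluorophenyl gave a 2.9-fold lower number from compound 1 to compound 2 (0.47 log units; beyond the scatter), a modest step that replaced a whole ring. Placing fluoro where hydrogen stood gave a 1.0-fold lower number from compound 2 to compound 3 (0.01 log units; within the scatter), and this is the closer precedent, as it also alters only what sits on an aromatic carbon. No measured compound carries trifluoromethyl, so the effect of that group is not shown directly. Within the data shown here, with only that flat fluoro step as a guide, no change beyond the scatter is expected in this assay. The estimated step is a 1.1-fold lower number from compound 3 to compound 4 (0.05 log units; within the scatter). Compound 4 is estimated at 12000 nM, with an expected range of 5000 nM to 30000 nM.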

Compound 4, half-maximal effective concentration: 14200 nM
The estimate for compound 4 lay 1.2-fold (0.07 log units) below the measured number; low and high end bracket the measured number.
By their numbers in this assay, from the lowest: compounds 3, 2 and 4 (each within the scatter of the next); then compound 1.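

In this assay, trifluoromethyl, with its four heavy atoms, in place of the single fluoro atom gives a 1.0-fold higher number from compound 3 to compound 4 (0.02 log units; within the scatter) and so shows that this place on the aromatic ring, ortho to a large group and meta to a fluoro group, accepts a larger group without a shift beyond the scatter. Trifluoromethyl in place of hydrogen at the same place gives a 1.0-fold higher number from compound 2 to compound 4 (0.01 log units; within the scatter) in this comparison, which extends the earlier flat reading for hydrogen and fluoro to a third substituent, so that all three read alike here. Nothing on hand explains why these three substituents read alike in this assay.

What the compounds shown leave open is whether this flat reading would survive at the same place with an amine, a carboxylic acid or a longer chain, groups that differ from hydrogen, fluoro and trifluoromethyl in their atoms. They also leave open whether the same tolerance holds with a methoxy group in place of the fluoro group that remains on the ring of compound 4.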